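A few compounds are considered here, and "the series" means these few. Any claim that something is new, unique, unknown or untested is made for them only; others in the source may bear on it.

Series notes, measured compounds in an assay on cells (Kidney epithelial cell, kidney) for inhibition of sodium/hydrogen exchanger 3 (Rattus norvegicus), read by fluorescence, in the presence of a further agent that is not named here; on this read-out lower numbers stand for stronger inhibition and higher numbers for weaker inhibition:
- compound 1 `CN1Cc2c(Cl)cc(Cl)cc2C(c2cccc(S(=O)(=O)NCCOCCOCCNC(=O)C(O)C(O)NCCOCCOCCNS(=O)(=O)c3cccc(C4CN(C)Cc5c(Cl)cc(Cl)cc54)c3)c2)C1` gives 126 nM
- compound 2 `CN1Cc2c(Cl)cc(Cl)cc2[C@H](c2cccc(S(=O)(=O)NCCNC(=O)C(O)C(O)NCCNS(=O)(=O)c3cccc([C@@H]4CN(C)Cc5c(Cl)cc(Cl)cc54)c3)c2)C1` gives 501 nM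
- compound 3 `CN1Cc2c(Cl)cc(Cl)cc2[C@H](c2cccc(S(=O)(=O)NCCOCCOCCOCCNC(=O)NCCOCCOCCOCCNS(=O)(=O)c3cccc([C@@H]4CN(C)Cc5c(Cl)cc(Cl)cc54)c3)c2)C1` gives 12.6 nM

Compound 3 stands lowest of the three numbers in this assay; compound 1 sits at a higher number beyond the scatter, and compound 2 further still. Compound 4 `CN1Cc2c(Cl)cc(Cl)cc2C(c2cccc(S(=O)(=O)NCCOCCOCCOCCNC(=O)NCCOCCOCCOCCNS(=O)(=O)c3cccc(C4CN(C)Cc5c(Cl)cc(Cl)cc54)c3)c2)C1` is the next entry: the two compounds have the same atoms and bonds; at least one stereo element is drawn with a configuration in one of them and without one in the other: 2 of 2 stereo elements differ; a stereocentre at a saturated ring carbon is drawn S in compound 3 and without a configuration in compound 4; a stereocentre at a saturated ring carbon is drawn S in compound 3 and without a configuration in compound 4. Among the measured compounds shown here, no pair of measured compounds isolates such a change in drawn configuration, so nothing in the data sizes it. With the same atoms and bonds, compound 4 is expected to fall close to compound 3, with at most a small move toward a higher number if the undefined drawing covers a mixture, so the expected step of a 1.6-fold higher number from compound 3 to compound 4 (0.20 log units; within the scatter) is none beyond the scatter. For compound 4 the estimate in this assay is 20 nM, within 8 nM to 60 nM.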

Compound 4, half-maximal inhibitory concentration: 100 nM
Compound 4: middle estimate off by 5.0-fold (0.70 log units), on the low side; the measured number lies above the stated range.
By their numbers in this assay, from the lowest: compound 3; then compounds 4 and 1 (each within the scatter of the next); then compound 2.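

Configuration at the two saturated ring carbons is the first change in the series to stand alone, and in this assay it carries a 7.9-fold higher number from compound 3 to compound 4 (0.90 log units; beyond the scatter). The drawn S centres therefore go with the lower number, a link that no earlier comparison could size. With atoms and bonds the same, one difference remains to account for the step: the fact that one of compounds 3 and 4 is drawn with a defined configuration and the other without, at the place where they differ

Still open, as far as these compounds go, is what the undefined drawing of compound 4 contains, and how the form drawn R at both centres would read. Also open, from the compounds shown here alone, is whether the gap persists with a longer ethylene glycol chain around the same urea.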